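A Longer Chain on a Shared Core Under Cytotoxicity Testing

The compounds below may be only part of what the source reports. "The series", "measured", "known", "first", "only" and "open" are said of these compounds alone.

Compound 1 `CCCCNc1cncc(C(=O)NCc2ccccc2)n1` carries a butyl chain on a nitrogen of its aromatic core. In an ADME assay on HEL cells (Homo sapiens) for cytotoxicity, read by microscopy, with a stated time of 6 days (on this read-out lower numbers stand for higher toxicity in this test and higher numbers for lower toxicity in this test), compound 1 gives > 100000 nM, which is a limit of the assay rather than a measured number. Compound 2 `CCCCCCCCNc1nccnc1C(=O)NCc1ccccc1` bears a longer chain on a core of the same kind. In this assay compound 2 gives > 100000 nM, again a limit and not a number. Among the compounds with values here, compound 1 thus stands at the limit itself, where (the limit of > 100000 nM in this assay, at which 2 of the 2 values shown sit); no numerical spread exists among the measured compounds, and no step between them can be sized. Compound 3 `CCCCCNc1cncc(C(=O)NCc2ccccc2)n1` is the next member of the series. methyl in place of hydrogen on a saturated chain carbon, four bonds along the chain from a nitrogen on an aromatic ring Both measured compounds sit at the limit, so the methyl that enters in compound 3 is expected to leave the read-out where it already stands. The expected change a number no higher from compound 1 to compound 3 (the limit leaves the size open) in this assay is none beyond the scatter. Compound 3 is therefore expected to give 100000 nM in this assay, with a range from 50000 nM to 200000 nM, and most probably only a limit once more.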

Compound 3, minimum cytotoxic concentration: > 100000 nM
Compound 3 was reported as a limit; the forecaster's own chance of this, stated with the estimate: 80%; the middle value lies on the limit itself.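

Compound 3 and compound 1 are both reported only as limits, so no step between them can be read in this assay: the limit of > 100000 nM in this assay, at which 3 of the 3 values shown sit.

The compounds shown leave open where the true value of each one lies beyond that limit, and whether the added methyl changes the read-out at all.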